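A few compounds are considered here, and "the series" means these few. Any claim that something is new, unique, unknown or untested is made for them only; others in the source may bear on it.

Measured so far:
Compound 1 `COc1cccc(C(=O)Nc2nnc(/C=C/c3cc(OC)c(OC)c(OC)c3)s2)c1` gives 480 nM
Compound 2 `COc1ccc(/C=C/c2nnc(NC(=O)c3cc(OC)c(OC)c(OC)c3Br)s2)cc1` gives 550 nM

In a functional assay on MCF7 cells (Homo sapiens) for antiproliferative activity, read by MTT assay, with a stated time of 48 h (a higher number here means a weaker inhibitor, a lower number a stronger inhibitor), compound 2 gives 550 nM and so stands within the usual scatter of compound 1 at 480 nM with no order between them. Going by the values given here, compound 3 `COc1cccc(/C=C/c2nnc(NC(=O)c3cc(OC)c(OC)c(OC)c3Br)s2)c1` has the same atoms joined differently, with 3-methoxyphenyl in place of 4-methoxyphenyl on a double-bonded chain carbon bound to a double-bonded chain carbon as the only change. Among the compounds with values here, no measured pair shows this change, so in this assay no step beyond the scatter is expected in either direction. The expected change a 1.1-fold higher number from compound 2 to compound 3 (0.04 log units; within the scatter) is small. For compound 3 the estimate is 600 nM with 220 nM to 1800 nM as its expected range.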

Compound 3, half-maximal inhibitory concentration: 590 nM
For compound 3 the middle estimate is 1.0-fold (0.01 log units) above the measured one, within the range that was stated.
By their numbers in this assay, from the lowest: compounds 1, 2 and 3 (each within the scatter of the next).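

In this assay, 3-methoxyphenyl in place of 4-methoxyphenyl on a double-bonded chain carbon bound to a double-bonded chain carbon gives a 1.1-fold higher number from compound 2 to compound 3 (0.03 log units; within the scatter), which lies within the scatter. Going by these compounds alone, this is the first pair differing in one place only, and it shows that these two methoxyphenyl groups cannot be told apart at this position in this read-out. No measurement at hand offers an explanation for this result. On these data alone, whether an aminophenyl or a hydroxyphenyl group at the same place would also stay within the scatter remains open.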